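The source may report more compounds than this note shows. Statements on the series, on what has been measured and on what is new or still open speak of the compounds shown alone.

Measured in a functional assay on MCF7 cells (Homo sapiens) for antiproliferative activity, read by MTT assay, with a stated time of 48 h; a higher number here means a weaker inhibitor, a lower number a stronger inhibitor:
- Compound 1 `CC(C)=CCC[C@]1(C)/C=C/[C@@H](OC(=O)C=C(C)C)[C@](C)(O)/C=C/C(=O)/C(CN(C(C)C)C(C)C)=C\C1`: 780 nM
- Compound 2 `CC(C)=CCC[C@]1(C)/C=C/[C@@H](OC(=O)C=C(C)C)[C@](C)(O)/C=C/C(=O)/C(CN2CCN(C)CC2)=C\C1`: 550 nM

Among the compounds with values here, compound 2, at 550 nM, stands within the scatter of compound 1, the only other compound measured. Compound 3 `CC(C)=CCC[C@]1(C)/C=C/[C@@H](OC(=O)C=C(C)C)[C@](C)(O)/C=C/C(=O)/C(CN=[N+]=[N-])=C\C1` carries azido in place of 4-methylpiperazin-1-yl on a saturated chain carbon bound to a double-bonded ring carbon. Within the data shown here, the one measured step, a 1.4-fold lower number from compound 1 to compound 2 (0.15 log units; within the scatter), swapped diisopropylamino for 4-methylpiperazin-1-yl at that carbon. Among the measured compounds shown here, it is only a loose guide, as no measured compound carries azido. No change beyond the scatter is therefore expected in this assay, though with wide uncertainty. The expected step is a 1.3-fold higher number from compound 2 to compound 3 (0.10 log units; within the scatter). For compound 3 the estimated value is 700 nM, with an expected range of 220 nM to 2200 nM.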

Compound 3, half-maximal inhibitory concentration: 4890 nM
Beside the measured number, compound 3's estimate is 7.0-fold (0.84 log units) below it; the whole stated range lies below it.
By their numbers in this assay, from the lowest: compounds 2 and 1 (each within the scatter of the next); then compound 3.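

In this assay, the group on this saturated chain carbon bound to a double-bonded ring carbon clearly matters, which the two amines, within the scatter of each other, could not show. Azido brings an 8.9-fold higher number from compound 2 to compound 3 (0.95 log units; beyond the scatter) and a 6.3-fold higher number from compound 1 to compound 3 (0.80 log units; beyond the scatter) against the two amines, so the weaker result holds whichever amine it is compared with. Nothing measured here explains this difference. On these data alone, it remains open whether a primary amine, a hydroxyl or a plain hydrogen at this carbon would match the two amines or fall closer to azido.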